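Adding a Methyl Beside the Anilino Link of Compound 2

The compounds below may be only part of what the source reports. "The series", "measured", "known", "first", "only" and "open" are said of these compounds alone.

Measured compounds:
- compound 1 `Cc1cnc(Nc2ccc(S(C)(=O)=O)cc2)nc1Nc1nc2ccc(F)cc2s1`: > 50000 nM
- compound 2 `NS(=O)(=O)c1ccc(Nc2nccc(Nc3nc4ccc(F)cc4s3)n2)cc1`: 450 nM

Within the data shown here, compound 2 is the only member of this small set with a numerical result in a functional assay on HeLa cells (Homo sapiens) for antiproliferative activity, read by MTT assay, with a stated time of 48 h; a lower number here means a stronger inhibitor, a higher number a weaker inhibitor; there compound 2 gives 450 nM. The other result is a limit: in this assay compound 1 returns > 50000 nM, a limit of the assay rather than a number (the limit of > 50000 nM in this assay, at which 1 of the 2 values shown sits). Among the measured compounds shown here, compound 1 is a double departure from compound 2, with a methyl sulfone in place of the sulfonamide and with a methyl on its core, so no single step separates the two measured compounds.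

Compound 3 `Cc1cnc(Nc2ccc(S(N)(=O)=O)cc2)nc1Nc1nc2ccc(F)cc2s1` has not yet been measured. For the measured compounds named here, it keeps the sulfonamide of compound 2 and adds only one group: methyl in place of hydrogen on an aromatic carbon. Compound 3 thus also carries the methyl that compound 1 bears. Since compound 1 reached only a limit, the expectation for compound 3 is a step away from compound 2 toward weaker inhibition, of unsettled size. Compound 3 is expected to give 3000 nM, within 500 nM to 30000 nM, which would mean a step of a 6.7-fold higher number from compound 2 to compound 3 (0.82 log units; beyond the scatter).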

Compound 3, half-maximal inhibitory concentration: 3460 nM
Estimate against measurement, compound 3: 1.2-fold (0.06 log units) below; measured number inside the range.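

In this assay, methyl in place of hydrogen on the aromatic carbon gives a 7.7-fold higher number from compound 2 to compound 3 (0.89 log units; beyond the scatter). This position therefore does not take the added methyl without a loss, although compound 3 still returns a number rather than a limit. With the methyl present in both compounds, amino in place of methyl on the sulfonyl sulfur gives an at least 14-fold lower number from compound 1 to compound 3 (1.15 log units; beyond the scatter), which separates the sulfonyl change from the methyl that compound 1 and compound 3 share, but this step is only a bound, for compound 1 stands at a limit of the assay and not at a number: the limit of > 50000 nM in this assay, at which 1 of the 3 values shown sits.

The compounds shown leave open whether the loss belongs to methyl alone or would also follow from another group on this carbon, such as a chlorine atom, an ethyl group or an amine. Also open, as far as these compounds go, is how a methyl sulfone would read on the core without the methyl, and so whether the two changes in compound 1 simply add up.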